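The compounds below may be only part of what the source reports. "The series", "measured", "known", "first", "only" and "open" are said of these compounds alone.

In a functional assay on MDA-MB-231 cells (Homo sapiens) for antiproliferative activity, read by MTT assay, with a stated time of 48 h (on this read-out higher numbers stand for weaker inhibition and lower numbers for stronger inhibition), compound 2 `C=CS(=O)(=O)N1CCN(c2ncnc3sc(-c4ccc(C#N)cc4)cc23)CC1` gives 8050 nM as the lowest of three numbers, with compound 1 `C=CS(=O)(=O)N1CCN(c2ncnc3sc(-c4ccc(OC)cc4)cc23)CC1` at 29900 nM and compound 3 `C=CS(=O)(=O)N1CCN(c2ncnc3sc(-c4cn(S(=O)(=O)c5ccccc5)c5ccccc45)cc23)CC1` at 40400 nM both higher. Compound 4 `C=CS(=O)(=O)N1CCN(c2ncnc3sc(-c4c(C)noc4C)cc23)CC1` has not been measured yet. It differs from compound 2 by one change: 3,5-dimethyl-1,2-oxazol-4-yl in place of 4-cyanophenyl on an aromatic carbon with 3,5-dimethyl-1,2-oxazol-4-yl in place of 4-cyanophenyl on an aromatic carbon. Among the measured compounds shown here, the only measured single change is a 3.7-fold lower number from compound 1 to compound 2 (0.57 log units; beyond the scatter) and it is modest but beyond the scatter, made within the group at this same place. Compound 1 and compound 3 both carry other groups there and both sit higher than compound 2 does. A similarly modest step towards a higher number in this assay is therefore expected, estimated as a 2.2-fold higher number from compound 2 to compound 4 (0.35 log units; beyond the scatter) for this swap. For compound 4 the estimated value is 18000 nM within a range of 6000 nM to 45000 nM.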

Compound 4, half-maximal inhibitory concentration: 28200 nM
The estimate for compound 4 lay 1.6-fold (0.19 log units) below the measured number; measured number inside the range.
By their numbers in this assay, from the lowest: compound 2; then compounds 4, 1 and 3 (each within the scatter of the next).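

In this assay the change from 4-cyanophenyl to 3,5-dimethyl-1,2-oxazol-4-yl gives a 3.5-fold higher number from compound 2 to compound 4 (0.54 log units; beyond the scatter) and so does not hold the lowest number seen at this place. The change from 4-methoxyphenyl to the same five-membered ring gives a 1.1-fold lower number from compound 1 to compound 4 (0.03 log units; within the scatter) and these two groups cannot be told apart here. No measured evidence explains either step. As far as these compounds go, it remains open whether the lower number of compound 2 depends on the nitrile itself. An unsubstituted phenyl ring, or a phenyl ring carrying an amine or a carboxylic acid in place of the nitrile, would bear on this.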